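The source may hold more compounds than are shown below. What is called first, only, known or untested is meant among the compounds shown, and "the series" means these compounds.

Measured so far:
compound 1 `COc1c(N(C)C(=O)CNC(=O)/C=C/c2ccc(C(F)(F)F)cc2)ccc(Cl)c1COc1cccc2ccc(C)nc12` — 2.8 nM
compound 2 `COc1ccc(N(C)C(=O)CNC(=O)/C=C/c2ccc(C(F)(F)F)cc2)c(Cl)c1COc1cccc2ccc(C)nc12` — 260 nM
compound 3 `Cc1ccc(/C=C/C(=O)NCC(=O)N(C)c2ccc(Cl)c(COc3cccc4sc(C)nc34)c2Cl)cc1` — 66 nM

All numbers come from a functional assay for inhibition, with Oryctolagus cuniculus as the target; on this read-out lower numbers stand for an effect already at smaller amounts and higher numbers for an effect only at larger amounts of compound. Compound 3 holds the second highest of the three; compound 2 is its nearest neighbour with a higher number, beyond the scatter, and compound 1 lies furthest with a lower number, also beyond the scatter. No pair of these compounds differs in a single place, so no counted step between measured compounds is at hand.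

Compound 4 `Cc1nc2c(OCc3c(Cl)ccc(N(C)C(=O)CNC(=O)/C=C/c4ccc(C(F)(F)F)cc4)c3Cl)cccc2s1` is not yet measured. It differs from compound 3 by trifluoromethyl in place of methyl on an aromatic carbon, para to a large group. Compounds 1 and 2 carry the trifluoromethyl on a different core and give only a loose hint. A moderate step towards a lower number is expected from compound 3 to compound 4, a 2.2-fold lower number from compound 3 to compound 4 (0.34 log units; beyond the scatter). Compound 4 is expected at 30 nM, within 8 nM to 120 nM.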

Compound 4, half-maximal effective concentration: 76 nM
The estimate for compound 4 lay 2.5-fold (0.40 log units) below the measured number; the measured number falls inside the stated range.
By their numbers in this assay, from the lowest: compound 1; then compounds 3 and 4 (each within the scatter of the next); then compound 2.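

In this assay, trifluoromethyl in place of methyl on an aromatic carbon, para to a large group, gives a 1.2-fold higher number from compound 3 to compound 4 (0.06 log units; within the scatter) on the shared core. For the compounds shown here, this is the first direct reading of this change, and at this position the two groups cannot be told apart. No measured evidence bears on why this is so.

From the compounds shown here alone, whether the same change would read alike on the core of compound 1 stays open. Also open, going by these compounds, is whether a different group at this position, such as an amine or a carboxylic acid, would shift the number beyond the scatter.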